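A few compounds are considered here, and "the series" means these few. Any claim that something is new, unique, unknown or untested is made for them only; others in the source may bear on it.

Measured so far in a physicochemical assay for solubility, read by HPLC, measured as kinetic solubility; a lower number here means a less soluble compound, a higher number a more soluble compound
- compound 1 `COc1ccc(-c2ccc(O[C@@H]3COc4nc([N+](=O)[O-])cn4C3)nc2)cn1` gives 18 ug/mL
- compound 2 `O=[N+]([O-])c1cn2c(n1)SC(COCc1ccc(OCc3ccccc3)cc1)C2` gives 1.2 ug/mL

Compound 2 at 1.2 ug/mL is the lower of the two numbers, and its gap to compound 1 at 18 ug/mL lies beyond the scatter. Going by the values given here, no two measured compounds differ in one place only, so the series offers no measured step to borrow from.

Compound 3 `CC1(COCc2ccc(OCc3ccccc3)cc2)Cn2cc([N+](=O)[O-])nc2S1` has not yet been measured in this assay and differs from compound 2 by methyl in place of hydrogen on a saturated ring carbon with methyl in place of hydrogen on a saturated ring carbon. The only direct reference for it is compound 2 at 1.2 ug/mL and the gap between the two measured compounds says nothing about this particular change. The expectation is therefore no step beyond the scatter, with a slight lean towards a lower number. The estimated step is a 1.2-fold lower number from compound 2 to compound 3 (0.08 log units; within the scatter) and it is expected to stay within the scatter. For compound 3 the expected value is 1 ug/mL (estimated range 0.4 ug/mL to 2.5 ug/mL).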

Compound 3, solubility: 1.2 ug/mL
The estimate for compound 3 lay 1.2-fold (0.08 log units) below the measured number; the range from low to high includes it.
By their numbers in this assay, from the lowest: compounds 2 and 3 (each within the scatter of the next); then compound 1.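

Methyl in place of hydrogen on a saturated ring carbon, next to the ring sulfur, is the first change in this series that can be read in one place, and in this assay it gives no change at the digits printed from compound 2 to compound 3 (within the scatter) with the rest of the structure held constant. This position therefore accepts the added methyl, a single carbon with no ring, no hydrogen-bond donors or acceptors and no net charge, without a step beyond the scatter, something the earlier pair, which differs in more than one place, could not show. No measured information accompanies this result that would explain it, so the flat step stands here only as an observation.

Going by these compounds, a single small group at one carbon does not define the tolerance of this position, so it remains open whether a longer chain, an amine or a carboxylic acid there would also stay within the scatter in this assay or would produce a real step. Also open, on these data alone, is whether the same methyl would give a comparable step on the core of compound 1, which has no partner differing from it in one place.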